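The source may hold more compounds than are shown below. What is called first, only, known or untested is meant among the compounds shown, and "the series" means these compounds.

In an ADME assay on WI-38 cells (Homo sapiens) for cytotoxicity, read by MTT assay, with a stated time of 72 h (on this read-out lower numbers stand for stronger inhibition and higher numbers for weaker inhibition), compound 1 `O=C(CCc1cccc2c1B(O)OC2)Nc1ccc(F)cc1`, which carries fluoro, gives 12000 nM. Compound 2 `O=C(CCc1cccc2c1B(O)OC2)Nc1ccc(Cl)cc1`, which carries chloro, gives > 100000 nM, and this is a limit of the assay and not a number. Compound 2 therefore has no exact place on the scale. Compound 3 `O=C(CCc1cccc2c1B(O)OC2)Nc1ccc(Br)cc1` differs from it by one substitution, bromo in place of chloro on an aromatic carbon.

Going by the values given here, only one measured step bears on this change, the swap of chloro in place of fluoro at the same carbon, and it is an at least 8.3-fold higher number from compound 1 to compound 2 (0.92 log units; beyond the scatter). That step lies beyond the scatter, but it ends on a limit, so it gives a direction and no exact size. A single step cannot establish a trend across the halogens. The expectation in this assay is therefore that compound 3 stays at weak inhibition, close to the top of the range, and it may also be reported only as a limit. The expected change is an at least 1.2-fold lower number from compound 2 to compound 3 (0.09 log units; that floor lies within the scatter). For compound 3 the estimated value is 80000 nM, with an expected range from 20000 nM to 200000 nM.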

Compound 3, half-maximal inhibitory concentration: 42000 nM
For compound 3 the middle estimate is 1.9-fold (0.28 log units) above the measured one, and the stated range covers the measured number.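

In this assay, the swap of chloro for bromo gives an at least 2.3-fold lower number from compound 2 to compound 3 (0.37 log units; beyond the scatter), so the direction seen on going from fluoro to chloro does not carry on to the next halogen at this aromatic carbon. Set against the fluoro compound, bromo still gives a 3.5-fold higher number from compound 1 to compound 3 (0.54 log units; beyond the scatter), which places compound 3 between compound 1 and compound 2 and shows that the three halogens do not rank in the order fluoro, chloro, bromo, with compound 2 the one that breaks that order. Compound 2 is held at a limit and not a number, so the step from it to compound 3 is known only as a floor, and how far chloro stands from the other two halogens stays unknown: the limit of > 100000 nM in this assay, at which 1 of the 3 values shown sits.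

The compounds shown differ only in this one halogen on the 4-halophenyl group, so they leave open whether a methoxy group, an amine or a carboxylic acid at the same carbon would fall inside or outside the span of these values. They also leave open whether the same ranking of the halogens would survive a longer chain in the shared core, and they give no cause for the ranking itself.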